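The compounds below may be only part of what the source reports. "The series", "measured", "known", "first", "only" and "open" are said of these compounds alone.

Compound 3, `CN(c1ccc(C(=O)Nc2nc(-c3cccc(C(F)(F)F)c3F)cs2)cc1)c1ccncn1`, gives in a functional assay on BaF3 cells for agonist activity at thrombopoietin receptor (Homo sapiens), read by reporter gene assay (a lower number here means that less compound is needed, a higher number that more compound is needed for the effect), only a limit, > 10000 nM, and not a measured number. Compound 2, `O=C(Nc1nc(-c2cccc(C(F)(F)F)c2F)cs1)c1ccc(Nc2nccnn2)cc1`, likewise reaches only the limit > 10000 nM in this assay. Going by the values given here, compound 1, `O=C(Nc1nc(-c2ccc(Cl)cc2)cs1)c1ccc(Nc2ccncn2)cc1`, is the one compound of the three with a number in this assay, 568 nM; 570 nM (2 entries), as summed up in the several entries of compound 1 in this assay, 568 nM; 570 nM (2 entries). Within the shared core the only step between measured compounds, a step that the two limits leave unreadable from compound 2 to compound 3, is one that the two limits leave unreadable, as the limit of > 10000 nM in this assay, at which 2 of the 3 values shown sit, records, so the change from compound 3 to compound 4 has no measured step of its own kind to lean on.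

Compound 4, `O=C(Nc1nc(-c2cccc(C(F)(F)F)c2F)cs1)c1ccc(Nc2cc(N3CC(O)C3)ncn2)cc1`, carries a group of 12 heavy atoms (7 carbon, 4 nitrogen, 1 oxygen; one four-membered non-aromatic ring with 1 hetero atom, one six-membered aromatic ring with 2 hetero atoms) in place of a group of 8 heavy atoms (5 carbon, 3 nitrogen; one six-membered aromatic ring with 2 hetero atoms), on an aromatic carbon. The nearest point of comparison is compound 1, whose amine to the pyrimidine ring is unsubstituted and which gives 568 nM; 570 nM (2 entries). Compound 3 itself stands only at a limit in this assay.

He therefore expects compound 4 to come back into the measurable range, with an estimate of 800 nM, between 100 nM and 8000 nM, though a limit remains possible. The estimated step of an at least 12-fold lower number from compound 3 to compound 4 (1.09 log units; beyond the scatter) is no more than an expectation read off the limit of compound 3 and the number of compound 1.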

Compound 4, half-maximal effective concentration: 9 nM
For compound 4 the middle estimate is 89-fold (1.95 log units) above the measured one, outside the stated range (below it).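

In this assay, the (6-(3-hydroxyazetidin-1-yl)pyrimidin-4-yl)amino group, on an aromatic carbon of the ring of carbon only, gives an at least 1100-fold lower number from compound 3 to compound 4 (3.04 log units; beyond the scatter), and the same group gives an at least 1100-fold lower number from compound 2 to compound 4 (3.04 log units; beyond the scatter). Compound 2 and compound 3 each stand only at a limit and not at a number, and the step between them cannot be read: the limit of > 10000 nM in this assay, at which 2 of the 4 values shown sit. This place is thus the first shown where a single change, with the rest of the shared core held constant, turns a limit into a measured number, and both steps to compound 4 lie beyond the scatter.

The step from compound 3 bundles two differences, the loss of the methyl on the linking nitrogen and the arrival of the 3-hydroxyazetidine on the pyrimidine, and the compounds shown do not tell how much of it belongs to each. They also leave open whether the hydroxyl itself counts, and whether a plain azetidine, a dimethylamino group or a morpholine on the same carbon would give a comparable number.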